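This account rests on a few compounds, and the source may have more. Where it says the series, first, only, none or still open, it means among the compounds named here.

Going by the values given here, in a functional assay on MCF7 cells (Homo sapiens) for inhibition, read by sulforhodamine B assay (on this read-out higher numbers stand for weaker inhibition of growth and lower numbers for stronger inhibition of growth), compound 3 (`Oc1ccc(-c2ccc(-c3ccc(-c4nc5c(O)cccc5[nH]4)cc3)cc2)cc1`) gives 190 nM, the lowest of the three numbers measured so far. Compound 2 (`Oc1cccc2[nH]c(-c3ccc(-c4ccc(-c5ccc(F)cc5)cc4)cc3)nc12`) gives 3010 nM, and compound 1 (`COc1ccc(-c2ccc(-c3ccc(-c4nc5ccccc5[nH]4)cc3)cc2)cc1OC`) gives 7600 nM. Both numbers lie well beyond the scatter from that of compound 3.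

Compound 4 (`COc1ccc(-c2ccc(-c3ccc(-c4nc5c(O)cccc5[nH]4)cc3)cc2)cc1OC`) differs from compound 3 in one place: 3,4-dimethoxyphenyl in place of 4-hydroxyphenyl on an aromatic carbon. The 3,4-dimethoxyphenyl replaces the 4-hydroxyphenyl, so the free hydroxy on that end group is lost.

Among the compounds with values here, one measured step bears directly on this change: a 16-fold lower number from compound 2 to compound 3 (1.20 log units; beyond the scatter). This large step involves the same position, and it suggests that losing the hydroxy there could cost much of the growth inhibition. Compound 1, at 7600 nM, carries the same 3,4-dimethoxyphenyl but lacks the hydroxy on the core that compound 3 and compound 4 share, so it is only a loose guide.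

A large step towards weaker inhibition is therefore expected, estimated as an 11-fold higher number from compound 3 to compound 4 (1.02 log units; beyond the scatter). For compound 4 the estimated value is 2000 nM, with an expected range from 600 nM to 7000 nM.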

Compound 4, concentration for 50% growth inhibition: 190 nM
Compound 4: middle estimate off by 11-fold (1.02 log units), on the high side, outside the stated range (below it).
By their numbers in this assay, from the lowest: compounds 3 and 4 (each within the scatter of the next); then compound 2; then compound 1.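

In this assay the swap at this position gives no change at the digits printed from compound 3 to compound 4 (within the scatter) and so the free hydroxy on the end group is not needed to keep this level of growth inhibition when 3,4-dimethoxyphenyl takes the place of 4-hydroxyphenyl. With the hydroxy on the shared core present, replacing 4-fluorophenyl gives a 16-fold lower number from compound 2 to compound 4 (1.20 log units; beyond the scatter) so both 3,4-dimethoxyphenyl and 4-hydroxyphenyl stand well apart from 4-fluorophenyl here. That core hydroxy matters even with the 3,4-dimethoxyphenyl in place, as adding it in place of hydrogen gives a 40-fold lower number from compound 1 to compound 4 (1.60 log units; beyond the scatter) and this is a large step.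

No measurement offered here explains any of these steps. As far as these compounds go, it remains open whether 4-methoxyphenyl, or an end ring carrying an amine or a carboxylic acid, would fit this position equally well.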